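The source may hold more compounds than are shown below. What is called first, only, known or untested is meant among the compounds shown, and "the series" means these compounds.

Three measured compounds share one core and differ only in the group on the triple-bonded carbon. Compound 1 `CC(=O)OCC(CCn1cc(C#Cc2cc(F)cc(F)c2)c(=O)n(C(=O)c2ccccc2)c1=O)COC(C)=O` gives 64500 nM in a functional assay on HeLa cells (Homo sapiens) for antiproliferative activity, read by MTT assay, with a stated time of 72 h; on this read-out higher numbers stand for weaker inhibition and lower numbers for stronger inhibition; compound 2 `CC(=O)OCC(CCn1cc(C#Cc2ccc(Br)cc2)c(=O)n(C(=O)c2ccccc2)c1=O)COC(C)=O` gives 47200 nM; compound 3 `CC(=O)OCC(CCn1cc(C#CCc2ccccc2)c(=O)n(C(=O)c2ccccc2)c1=O)COC(C)=O` gives 29900 nM. Compound 2 stands second highest of the three: a 1.4-fold lower number from compound 1 to compound 2 (0.14 log units; within the scatter), and a 1.6-fold lower number from compound 2 to compound 3 (0.20 log units; within the scatter); the widest step is a 2.2-fold lower number from compound 1 to compound 3 (0.33 log units; beyond the scatter). Compound 4 `CC(=O)OCC(CCn1cc(C#CC(C)(C)C)c(=O)n(C(=O)c2ccccc2)c1=O)COC(C)=O` carries tert-butyl in place of 4-bromophenyl on a triple-bonded carbon. Within the data shown here, none of the measured steps trades a six-membered aromatic ring for a group with no ring, so the three steps above are the only guide, and each is modest or within the scatter. For compound 4 no step beyond the scatter is therefore expected: a 1.1-fold higher number from compound 2 to compound 4 (0.03 log units; within the scatter). Compound 4 is estimated at 50000 nM, in a range from 20000 nM to 125000 nM.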

Compound 4, half-maximal inhibitory concentration: 71500 nM
For compound 4 the middle estimate is 1.4-fold (0.16 log units) below the measured one; the measured number falls inside the stated range.
By their numbers in this assay, from the lowest: compounds 3, 2, 1 and 4 (each within the scatter of the next, the first and the last beyond it).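

Tert-butyl, the first group here with no ring on the triple-bonded carbon, leaves the number level with the aryl compounds in this assay: a 1.5-fold higher number from compound 2 to compound 4 (0.18 log units; within the scatter) and a 1.1-fold higher number from compound 1 to compound 4 (0.04 log units; within the scatter) both hold, so a six-membered aromatic ring is not required at this position to keep these values. Only benzyl stands apart, with a 2.4-fold higher number from compound 3 to compound 4 (0.38 log units; beyond the scatter) as a modest step. No measurement at hand bears on the reason for these numbers.

Going by these compounds, whether an amine, a carboxylic acid or a longer chain on this carbon would leave this narrow band remains open.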